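The source may report more compounds than this note shows. Statements on the series, on what has been measured and on what is new or still open speak of the compounds shown alone.

Measured compounds in an ADME assay on SH-SY5Y cells (Homo sapiens) for cytotoxicity, read by MTT assay, with a stated time of 72 h; a higher number here means that more compound is tolerated, a lower number that less compound is tolerated:
Compound 1 `c1coc(-c2cn3ccccc3n2)c1` gives > 100000 nM, which is a limit of the assay.
Compound 2 `c1ccc(-c2cn3cc(-c4ccco4)ccc3n2)cc1` gives > 100000 nM, also a limit of the assay.
Compound 3 `Nc1cc(-c2ccco2)cn2cc(-c3ccccc3)nc12` gives 26000 nM.

Within the data shown here, the one change between compound 2 and compound 3 is amino in place of hydrogen on an aromatic carbon. That step came out as an at least 3.8-fold lower number from compound 2 to compound 3 (0.58 log units; beyond the scatter), so less of compound 3 is tolerated than of compound 2. Compound 4 `Nc1cccn2cc(-c3ccco3)nc12` is not yet measured; it differs from compound 1 by amino in place of hydrogen on an aromatic carbon. The place is the same kind of change, not the same: around the place in compound 2 there is in addition a furan-2-yl group (5 heavy atoms) meta to it, which compound 1 lacks. The difference between the two cores is not broken down here. For compound 1 only a limit is known, and the limit of > 100000 nM in this assay, at which 2 of the 3 values shown sit, leaves the starting point open. Still, resting on an at least 3.8-fold lower number from compound 2 to compound 3 (0.58 log units; beyond the scatter), a step of about an at least 2.5-fold lower number from compound 1 to compound 4 (0.39 log units; beyond the scatter) is expected from compound 1 to compound 4. Compound 4 is therefore estimated at 40000 nM, within 12000 nM to 110000 nM.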

Compound 4, half-maximal cytotoxic concentration: > 100000 nM
Compound 4 was reported as a limit (the forecaster's own chance of this, stated with the estimate: 35%); middle value at least 2.5-fold (0.39 log units) from the limit.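

Compound 1 and compound 4 both sit at a limit in this assay, so no step between them can be read: the limit of > 100000 nM in this assay, at which 3 of the 4 values shown sit.

From the compounds shown here alone, whether amino in place of hydrogen lowers the number at all on the core of compound 1, as it does from compound 2 to compound 3, stays open.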